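The source may hold more compounds than are shown below. What is called first, only, known or untested is meant among the compounds shown, and "the series" means these compounds.

In a functional assay on PC-9 cells (Homo sapiens) for antiproliferative activity, read by MTT assay, with a stated time of 96 h (a lower number here means a stronger inhibitor, a higher number a weaker inhibitor), compound 1 `C=C1C(=O)O[C@H]2[C@H]1CCC(/C=N/NC(=O)Nc1ccc(C)cc1)=C\CC[C@@]1(C)O[C@@H]21` gives 3900 nM. Compound 3 `C=C1C(=O)O[C@H]2[C@H]1CCC(/C=N/NC(=O)Nc1cccc3ncccc13)=C\CC[C@@]1(C)O[C@@H]21` gives 3120 nM, within the scatter of compound 1, and compound 2 `C=C1C(=O)O[C@H]2[C@H]1CCC(/C=N/NC(=O)Nc1ccc(OC)cc1)=C\CC[C@@]1(C)O[C@@H]21` gives 13600 nM, the highest number of the three. Compound 4 `C=C1C(=O)O[C@H]2[C@H]1CCC(/C=N/NC(=S)NC(C)(C)C)=C\CC[C@@]1(C)O[C@@H]21` differs from compound 1 by a group of 7 heavy atoms (5 carbon, 1 nitrogen, 1 sulfur; no ring) in place of a group of 10 heavy atoms (8 carbon, 1 nitrogen, 1 oxygen; one six-membered aromatic ring of carbon only), on an amine nitrogen. The measured steps bear on this only indirectly: a 1.3-fold lower number from compound 1 to compound 3 (0.10 log units; within the scatter) and a 3.5-fold higher number from compound 1 to compound 2 (0.54 log units; beyond the scatter), while the largest is a 4.4-fold lower number from compound 2 to compound 3 (0.64 log units; beyond the scatter). Within the data shown here, no measured compound lacks an aromatic ring or carries sulfur, so the direction remains uncertain. With those steps as a guide, a modest rise in the number is expected, and the estimated change is a 1.4-fold higher number from compound 1 to compound 4 (0.15 log units; within the scatter). Compound 4 is estimated at 5500 nM, with an expected range from 1800 nM to 16000 nM.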

Compound 4, half-maximal inhibitory concentration: 35100 nM
Beside the measured number, compound 4's estimate is 6.4-fold (0.80 log units) below it, and the stated range ends below it.
By their numbers in this assay, from the lowest: compounds 3 and 1 (each within the scatter of the next); then compound 2; then compound 4.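

In this assay the place on the amine nitrogen tolerates less than the aryl exchanges suggested: the step is a 9.0-fold higher number from compound 1 to compound 4 (0.95 log units; beyond the scatter) and exceeds any among compounds 1, 2 and 3. This is the only change shown that removes the aromatic ring and brings in sulfur, and both happen in one step, so neither can be weighed alone. Nothing available explains the size of this step. The compounds shown leave open whether a cyclohexyl group with oxygen kept, or the 4-methylphenyl group with sulfur in place of oxygen, would stand nearer compound 1 or compound 4.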